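The compounds below may be only part of what the source reports. "The series", "measured", "known", "first", "only" and "open" are said of these compounds alone.

Going by the values given here, compound 2 `COc1ccc(C(=O)/C=C/c2cc(-c3cc(OC)c(OC)c(OC)c3)n[nH]2)cc1` gives 3080 nM in a functional assay on SF-539 cells (Homo sapiens) for inhibition, read by sulforhodamine B assay, with a stated time of 48 h (a higher number here means a weaker inhibitor of growth, a lower number a stronger inhibitor of growth), the lowest of the two numbers so far. Compound 1 `COc1cc(-c2cc(/C=C/C(=O)c3ccc(Cl)c(Cl)c3)[nH]n2)cc(OC)c1OC` gives 18700 nM; the step of a 6.1-fold lower number from compound 1 to compound 2 (0.78 log units; beyond the scatter) is the only measured one. Compound 3 `COc1cc(-c2cc(/C=C/C(=O)c3ccc(F)c(F)c3)[nH]n2)cc(OC)c1OC` carries 3,4-difluorophenyl in place of 4-methoxyphenyl on a carbonyl carbon, which brings it closer to compound 1 than compound 2 is. Because that earlier step a 6.1-fold lower number from compound 1 to compound 2 (0.78 log units; beyond the scatter) moved away from a dihalophenyl toward the lower number, a step back toward a higher number is expected for compound 3, a 3.2-fold higher number from compound 2 to compound 3 (0.51 log units; beyond the scatter). Compound 3 is therefore estimated at 10000 nM, with a range from 4000 nM to 25000 nM.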

Compound 3, concentration for total growth inhibition: 17700 nM
Estimate against measurement, compound 3: 1.8-fold (0.25 log units) below; measured number inside the range.
By their numbers in this assay, from the lowest: compound 2; then compounds 3 and 1 (each within the scatter of the next).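

On the carbonyl carbon, the 3,4-difluorophenyl group reverses the gain seen with 4-methoxyphenyl, giving a 5.7-fold higher number from compound 2 to compound 3 (0.76 log units; beyond the scatter). Exchanging the two halogens, by contrast, gives a 1.1-fold lower number from compound 1 to compound 3 (0.02 log units; within the scatter), so among these three compounds the difference lies between 4-methoxyphenyl and the dihalophenyl groups, not between fluorine and chlorine. Nothing measured here explains this difference.

On these data alone, compound 2 alone carries the methoxy group, so it remains open whether the methoxy itself matters or simply the absence of halogens. A plain phenyl or a 4-aminophenyl group on the same carbon would help separate these.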